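The source may report more compounds than this note shows. Statements on the series, on what has been measured and on what is new or still open speak of the compounds shown alone.

compound 1 `O=C(Nc1ccc(F)cc1Cl)c1cc(Cl)ccc1O` gives 50.5 10^-6 cm/s
compound 2 `O=C(Nc1ccc(F)cc1F)c1cc(Cl)ccc1O` gives "not determined" (no result reported)
compound 3 `O=C(Nc1ccc(F)c(Cl)c1)c1cc(Cl)ccc1O` gives "not determined" (no result reported)

Only compound 1 has a number in an ADME assay for permeability, using PAMPA (on this read-out higher numbers stand for higher permeability and lower numbers for lower permeability), so far. Among the compounds with values here, compound 3 therefore has no place on the scale, and compound 2 is in the same position, so no step between measured compounds can be read from these data. Still unmeasured is compound 4 `O=C(Nc1ccc(F)cc1)c1cc(Cl)ccc1O`, which shares the core of compound 3 and differs from it in one place. The structural change is hydrogen in place of chloro on an aromatic carbon, ortho to a fluoro group.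

The data give no direct measure of what this exchange does in this assay. The expected step from the unknown level of compound 3 is therefore modest, with nothing beyond the usual scatter of repeated measurements and, if anything, a slight lean towards lower numbers. Within the data shown here, the only numerical anchor is compound 1 at 50.5 10^-6 cm/s, and that single value leaves the estimate wide. For compound 4 the estimated value is 35 10^-6 cm/s, with an expected range from 14 10^-6 cm/s to 75 10^-6 cm/s in this assay.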

Compound 4, apparent permeability: 391 10^-6 cm/s
For compound 4 the middle estimate is 11-fold (1.05 log units) below the measured one; the measured number lies above the stated range.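

In this assay, within the data shown here, the one step that can be read is a 7.7-fold higher number from compound 1 to compound 4 (0.89 log units; beyond the scatter) with hydrogen in place of chloro on an aromatic carbon, and it lies beyond the scatter. Among these compounds, it shows that the shared core with only the fluoro group on that ring stands well above the one chloro-bearing compound with a number, which a single value could not show. The steps to compound 4 from compound 2 and from compound 3, whose chloro sits ortho to a fluoro group, cannot be read, as neither compound has a number, and nothing at hand bears on why the number moves as it does.

On these data alone, how a chloro ortho to a fluoro group compares with the chloro of compound 1 therefore stays open, so this step cannot be carried over to the carbon that differs between compound 3 and compound 4. Also open, as far as these compounds go, is whether a methoxy group, an amine or a nitrile on either carbon would give numbers nearer compound 1 or nearer compound 4.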